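The compounds below may be only part of what the source reports. "The series", "measured", "known", "first", "only" and "open" are said of these compounds alone.

Compound 3 `CCCCCCCCc1ccc(NC(=O)[C@H](CO)NC)cc1` gives 2800 nM in an assay on isolated protein for inhibition of sphingosine kinase 1 (Homo sapiens), read by mobility shift assay; a lower number here means a stronger inhibitor, a higher number a weaker inhibitor. Of the two plain numbers shown it is the lower, yet its nearest neighbour, compound 1 `CCCCCCCCc1ccc(NC(=O)[C@@H](N)CO)cc1`, gives 4300 nM, and the step of a 1.5-fold lower number from compound 1 to compound 3 (0.19 log units; within the scatter) sits within the scatter, so these two cannot be told apart. For compound 2 `CCCCCCCCc1ccc(NC(=O)C(C)(N)CO)cc1` this assay reports only a limit, > 10000 nM, not a number. The step of an at least 2.3-fold higher number from compound 1 to compound 2 (0.36 log units; beyond the scatter) is nonetheless beyond the scatter, and the limit of > 10000 nM in this assay, at which 1 of the 3 values shown sits, marks where that value sits.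

Compound 4 `CCCCCCCCc1ccc(NC(=O)[C@@H](N)[C@@H](C)O)cc1` has yet to be tested. It differs from compound 3 by 1-amino-2-hydroxypropyl in place of 2-hydroxy-1-(methylamino)ethyl on a carbonyl carbon. Going by the values given here, two measured steps bear on this. The step of a 1.5-fold lower number from compound 1 to compound 3 (0.19 log units; within the scatter) shows that a methyl on the amine nitrogen changes little, so taking it away should cost little. The step of an at least 2.3-fold higher number from compound 1 to compound 2 (0.36 log units; beyond the scatter) shows that placing extra carbon on the group attached to the carbonyl carbon weakened inhibition at least modestly, and compound 4 likewise carries its methyl on that group rather than on the nitrogen. A weakening is therefore expected, though smaller and less certain than an at least 2.3-fold higher number from compound 1 to compound 2 (0.36 log units; beyond the scatter), since the methyl of compound 4 sits on the carbon bearing the hydroxyl instead.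

Compound 4 is expected to give about 5500 nM in this assay, somewhere between 1800 nM and 16000 nM, which means an expected step of a 2.0-fold higher number from compound 3 to compound 4 (0.29 log units; within the scatter).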

Compound 4, half-maximal inhibitory concentration: 650 nM
The estimate for compound 4 lay 8.5-fold (0.93 log units) above the measured number; the measured number lies below the stated range.
By their numbers in this assay, from the lowest: compound 4; then compounds 3 and 1 (each within the scatter of the next). At a limit, above all of these: compound 2.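

In this assay, adding a methyl to this group does not have to weaken inhibition, as a 6.6-fold lower number from compound 1 to compound 4 (0.82 log units; beyond the scatter) shows, and this is the only change shown that lowers the number beyond the scatter from compound 1. Where the atoms sit matters as well: 1-amino-2-hydroxypropyl in place of 2-hydroxy-1-(methylamino)ethyl on the carbonyl carbon gives a 4.3-fold lower number from compound 3 to compound 4 (0.63 log units; beyond the scatter), even though the two groups hold the same atoms, joined differently. Replacing 1-amino-1-(hydroxymethyl)ethyl with the same 1-amino-2-hydroxypropyl gives an at least 15-fold lower number from compound 2 to compound 4 (1.18 log units; beyond the scatter), so the extra carbon gives opposite results in these two groups, although the size of this step rests on compound 2 having a limit and not a number: the limit of > 10000 nM in this assay, at which 1 of the 4 values shown sits.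

On these data alone, it remains open whether an ethyl in place of the added methyl, or a methoxy in place of the hydroxyl, would keep this gain. Compound 4 also shows only one arrangement at its second stereocentre, so the part played by that arrangement is unknown, and the numbers give no reason for the gain itself.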